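The source may hold more compounds than are shown below. What is called first, only, known or untested is meant among the compounds shown, and "the series" means these compounds.

Compound 1 `CNC(=O)c1cc(Oc2ccc3nc(Nc4ccccc4)ncc3c2)ccn1` was examined in an ADME assay on Caco-2 cells (Homo sapiens) for permeability, in the apical to basolateral direction (on this read-out lower numbers stand for lower permeability and higher numbers for higher permeability), where compound 1 gives < 1 10^-6 cm/s, a limit of the assay rather than a number. Two close relatives of compound 1 are compound 2 `CNC(=O)c1cc(Oc2ccc3nc(Nc4cccc(Cl)c4)ncc3c2)ccn1` and compound 3 `CNC(=O)c1cc(Oc2ccc3nc(Nc4cccc(Br)c4)ncc3c2)ccn1`. In this assay compound 2 gives < 1 10^-6 cm/s, which is a limit. In this assay compound 3 gives < 1 10^-6 cm/s, again a limit. The step from compound 1 to compound 2 is a step that the two limits leave unreadable from compound 1 to compound 2, the step from compound 1 to compound 3 is a step that the two limits leave unreadable from compound 1 to compound 3, and the step from compound 2 to compound 3 is a step that the two limits leave unreadable from compound 2 to compound 3; all three rest on (the limit of < 1 10^-6 cm/s in this assay, at which 3 of the 3 values shown sit). The unmeasured compound 4 `CNC(=O)c1cc(Oc2ccc3nc(Nc4ccc(Oc5ccccc5)cc4)ncc3c2)ccn1` differs from compound 1 by phenoxy in place of hydrogen on an aromatic carbon. Among the measured compounds shown here, none of the measured steps offers a readable size, so they give no direction for this change, and compound 1 itself sits at the limit. Compound 4 is expected to remain close to that limit, with an estimated step that the limit leaves unreadable from compound 1 to compound 4. The estimated value for compound 4 is 0.8 10^-6 cm/s, within a range from 0.2 10^-6 cm/s to 3 10^-6 cm/s.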

Compound 4, apparent permeability: < 1 10^-6 cm/s
Compound 4: only a limit was reported; the forecaster's own chance of this, stated with the estimate: 65%; the middle value is on the limit's open side.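

No new step can be read between compound 1 and compound 4, as both stand at a limit in this assay. The compounds shown leave open how far each lies beyond that limit, and whether phenoxy, chloro or bromo in place of hydrogen changes the read-out at all.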